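This account rests on a few compounds, and the source may have more. Where it says the series, first, only, none or still open, it means among the compounds named here.

Working notes on the series. In a functional assay, tested at 200 ug/mL (on this read-out lower numbers stand for a stronger effect and higher numbers for a weaker effect at the one concentration tested), compound 1 `CCOC(=O)C1=C(C)N(c2ccccc2)C=CC1c1ccccc1` gives -29.3%. Compound 2 `CCOC(=O)C1=C(C)N(c2ccc(Cl)cc2)C=CC1c1ccccc1` carries chloro in place of hydrogen on an aromatic carbon; in this assay compound 2 gives -31.1%, so that a number 1.8 percentage points lower from compound 1 to compound 2 (within the scatter). Compound 3 `COC(=O)C1=C(C)N(c2ccccc2)C=C(C)C1c1ccccc1` has a core that differs from the core of compound 1, and the difference between the two cores is not broken down here; in this assay compound 3 gives -33.1%. Compound 4 `COC(=O)C1=C(C)N(c2cccc(Cl)c2)C=C(C)C1c1ccccc1` is not yet measured. It differs from compound 3 by chloro in place of hydrogen on an aromatic carbon, the same kind of change as from compound 1 to compound 2, the chloro standing meta to a large group here where it stood para to a large group there. The step of a number 0.9 percentage points lower from compound 3 to compound 4 (within the scatter) is expected, resting on a number 1.8 percentage points lower from compound 1 to compound 2 (within the scatter). For compound 4 the estimate is -34%, between -44% and -24%.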

Compound 4, a percentage reported as activity, at one concentration (the size of the read-out at that concentration, not a potency): -23%
Compound 4: middle estimate off by 11 percentage points, on the low side, and the stated range ends below it.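

In this assay, chloro in place of hydrogen on an aromatic carbon gives a number 10.1 percentage points higher from compound 3 to compound 4 (beyond the scatter). Set beside the earlier step on the core of compound 1, this step does not differ from it by more than the scatter allows: the same change on two cores in this assay, a number 1.8 percentage points lower (within the scatter) from compound 1 to compound 2 and a number 10.1 percentage points higher (beyond the scatter) from compound 3 to compound 4, 11.9 percentage points apart, within the scatter of two such steps. This does not show that the core changes the effect of the chloro, nor that the effect carries over unchanged, and with the chloro meta to a large group in compound 4 but at another place on the ring in compound 2, core and position cannot be told apart.

Still open, from the compounds shown here alone, is how chloro behaves at one and the same place on both cores. Also open, going by these compounds, is how other groups on that ring, such as methoxy, an amine or a carboxylic acid, behave on either core.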